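The source may hold more compounds than are shown below. What is called first, only, known or untested is meant among the compounds shown, and "the series" means these compounds.

Measured so far in a functional assay on DU-145 cells (Homo sapiens) for cytotoxicity, read by CCK-8 assay; on this read-out higher numbers stand for weaker inhibition and lower numbers for stronger inhibition:

Compound 1 `Oc1ccc(-c2cc(-c3cccs3)cc(-c3cccc(O)c3)n2)cc1` gives 1890 nM in this assay.
Compound 2 `Oc1ccc(-c2cc(-c3ccsc3)cc(-c3cccc(O)c3)n2)cc1` gives 2230 nM in this assay.
Compound 3 `Oc1ccc(-c2cc(-c3ccco3)cc(-c3ccccc3O)n2)cc1` gives only a limit, > 50000 nM, in this assay.

Compound 3 stands apart from the other two: its result is a limit of this assay and not a number, at the limit of > 50000 nM in this assay, at which 1 of the 3 values shown sits, whereas compound 1 and compound 2 each give a measured value. The step of a 1.2-fold higher number from compound 1 to compound 2 (0.07 log units; within the scatter) shows that exchanging one thiophene attachment for the other leaves the read-out within the scatter.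

Compound 4 `Oc1ccc(-c2cc(-c3ccco3)cc(-c3cccc(O)c3)n2)cc1` differs from compound 3 in one place: 3-hydroxyphenyl in place of 2-hydroxyphenyl on an aromatic carbon. Within the data shown here, no measured step covers this particular change; the only measured step, from compound 1 to compound 2, concerns a different position and was within the scatter. Compound 1 and compound 2 both carry the 3-hydroxyphenyl group that enters here, and both give measured values, while compound 3, carrying 2-hydroxyphenyl, gives only a limit. On that basis compound 4 is expected to return a measurable value, so the step of an at least 12-fold lower number from compound 3 to compound 4 (1.09 log units; beyond the scatter) is expected to run toward stronger inhibition. Compound 4 is thus estimated at 4000 nM, with a range from 1500 nM to 30000 nM.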

Compound 4, half-maximal inhibitory concentration: 2070 nM
Compound 4: the middle estimate sits 1.9-fold (0.29 log units) above what was measured; low and high end bracket the measured number.
By their numbers in this assay, from the lowest: compounds 1, 4 and 2 (each within the scatter of the next). At a limit, above all of these: compound 3.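

In this assay, among these compounds, 3-hydroxyphenyl in place of 2-hydroxyphenyl, at the position next to the ring nitrogen, gives the first step beyond the scatter: an at least 24-fold lower number from compound 3 to compound 4 (1.38 log units; beyond the scatter). Compound 3 gives a limit and not a number, so this step has no exact size: the limit of > 50000 nM in this assay, at which 1 of the 4 values shown sits. With 3-hydroxyphenyl in place, the change among the aromatic rings stays within the scatter in both steps, a 1.1-fold lower number from compound 2 to compound 4 (0.03 log units; within the scatter) and a 1.1-fold higher number from compound 1 to compound 4 (0.04 log units; within the scatter), so furan-2-yl joins the two thiophene groups in that comparison.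

The compounds shown leave open whether 2-hydroxyphenyl gives the same result alongside thiophen-2-yl or thiophen-3-yl as it does alongside furan-2-yl. They also leave open how an amine or a carboxylic acid would read in place of the hydroxy group on the 3-hydroxyphenyl ring.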